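The source may report more compounds than this note shows. Statements on the series, on what has been measured and on what is new or still open speak of the compounds shown alone.

Working notes on the nitroaromatic anilide series, assessed in a functional assay on LNCaP cells (Homo sapiens) for antiproliferative activity, read by MTT assay, with a stated time of 96 h; a lower number here means a stronger inhibitor, a higher number a weaker inhibitor.

Compound 1 `CC(CSc1ccc(F)cc1)C(=O)Nc1ccc([N+](=O)[O-])c(C(F)(F)F)c1` gives 27200 nM in this assay. Compound 2 `CC(CSc1ccc(C(F)(F)F)cc1)C(=O)Nc1ccc([N+](=O)[O-])c(C(F)(F)F)c1` gives 4410 nM. Among the compounds with values here, the only change between the two is trifluoromethyl in place of fluoro on an aromatic carbon, and it produces a 6.2-fold lower number from compound 1 to compound 2 (0.79 log units; beyond the scatter).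

Compound 3 `CC(CSc1ccc(F)cc1)C(=O)Nc1ccc([N+](=O)[O-])cc1C(F)(F)F` carries the same atoms as compound 1 joined differently; the difference between the two cores is not broken down here. In this assay compound 3 gives 43200 nM, which sits within the scatter of compound 1 and is the highest number among the three measured compounds, with compound 2 well beyond the scatter below it.

Compound 4 `CC(CSc1ccc(C(F)(F)F)cc1)C(=O)Nc1ccc([N+](=O)[O-])cc1C(F)(F)F` stands to compound 3 as compound 2 stands to compound 1: the change is trifluoromethyl in place of fluoro on an aromatic carbon, the same change as from compound 1 to compound 2, made at the same place, on an aromatic carbon of a six-membered aromatic ring of carbon only, para to a large group. The change has been seen twice among these compounds, measured once.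

Within the data shown here, the step from compound 3 to compound 4 in this assay is expected to resemble the earlier one, estimated as a 5.4-fold lower number from compound 3 to compound 4 (0.73 log units; beyond the scatter), because the single measured instance, a 6.2-fold lower number from compound 1 to compound 2 (0.79 log units; beyond the scatter), was made on the core of compound 1 and the core of compound 3 differs from it in a way not broken down here, so some departure from that size is allowed for. Compound 4 is accordingly estimated at 8000 nM, with a plausible range from 3000 nM to 25000 nM.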

Compound 4, half-maximal inhibitory concentration: 54300 nM
Beside the measured number, compound 4's estimate is 6.8-fold (0.83 log units) below it, outside the stated range (above it).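

On the second core, trifluoromethyl in place of fluoro on an aromatic carbon gives a 1.3-fold higher number from compound 3 to compound 4 (0.10 log units; within the scatter) in this assay, so the change does not carry over at the same size from one core to the other: the same change on two cores in this assay, a 6.2-fold lower number (0.79 log units; beyond the scatter) from compound 1 to compound 2 and a 1.3-fold higher number (0.10 log units; within the scatter) from compound 3 to compound 4, 7.8-fold (0.89 log units) apart, beyond the scatter of two such steps. Among the compounds shown, the drop in the number is therefore confined to the core of compound 1, and the change cannot be treated as a fixed increment across the series. With a single pair on each core, the data do not show which feature of the cores separates the two outcomes, nor which of the two outcomes would be the more typical on a further core.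

The compounds shown leave open how chloro or methoxy in place of fluoro, at the same place on the aromatic ring, would behave on each of the two cores, and so whether the split between cores is peculiar to trifluoromethyl or extends to other groups. They also leave open whether a nitrile in place of the nitro group on the anilide ring would preserve or remove the difference between the cores.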